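Hydroxy added to a bromophenyl amide: cytotoxicity expectation

A few compounds are considered here, and "the series" means these few. Any claim that something is new, unique, unknown or untested is made for them only; others in the source may bear on it.

Measured compounds:
compound 1, `O=C(Nc1cccc(Cl)c1)c1cccc(Br)c1`, 51000 nM
compound 2, `O=C(Nc1ccc(Sc2nc3ccccc3s2)c(Cl)c1)c1cccc(Br)c1O`, 64000 nM
compound 3, `O=C(Nc1ccc(Sc2nc3ccccc3s2)c(Cl)c1)c1cccc(Br)c1`, > 100000 nM

Of the compounds shown here, three have been tested in an ADME assay on HEK293 cells (Homo sapiens) for cytotoxicity, read by reporter gene assay and resazurin assay, with a stated time of 48 h; on this read-out lower numbers stand for higher toxicity in this test and higher numbers for lower toxicity in this test. Compound 1 has the structure `O=C(Nc1cccc(Cl)c1)c1cccc(Br)c1` and in this assay gives 51000 nM. Compound 2, `O=C(Nc1ccc(Sc2nc3ccccc3s2)c(Cl)c1)c1cccc(Br)c1O`, gives 64000 nM in this assay. Compound 3, `O=C(Nc1ccc(Sc2nc3ccccc3s2)c(Cl)c1)c1cccc(Br)c1`, is reported in this assay only as a limit, > 100000 nM; its value sits at the limit of > 100000 nM in this assay, at which 1 of the 3 values shown sits. The values of compound 1 and compound 2 lie within the scatter of each other.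

Compound 3 and compound 2 differ in one place: hydroxy in place of hydrogen on an aromatic carbon. In this assay that change gave an at least 1.5-fold lower number from compound 3 to compound 2 (0.19 log units; that floor lies within the scatter).

Compound 4, `O=C(Nc1cccc(Cl)c1)c1cccc(Br)c1O`, has not yet been measured in this assay. It differs from compound 1 by hydroxy in place of hydrogen on an aromatic carbon, the same kind of change as that from compound 3 to compound 2; the descriptions of its place agree word for word, so it is the same change. The difference between the core of compound 1 and the core of compound 3 is not broken down here.

The expectation for compound 4 rests on compound 1 giving 51000 nM and on the measured step of an at least 1.5-fold lower number from compound 3 to compound 2 (0.19 log units; that floor lies within the scatter). A step of about a 1.5-fold lower number from compound 1 to compound 4 (0.16 log units; within the scatter) is expected for compound 4. Compound 4 is therefore estimated at 35000 nM, with a range from 15000 nM to 80000 nM expected.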

Compound 4, half-maximal cytotoxic concentration: 32000 nM
Beside the measured number, compound 4's estimate is 1.1-fold (0.04 log units) above it, and the stated range covers the measured number.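

In this assay, hydroxy in place of hydrogen on an aromatic carbon, ortho to a bromo group, gave a 1.6-fold lower number from compound 1 to compound 4 (0.20 log units; within the scatter). Taken together, the two cores show that this change can be carried from one to the other without a step that stands clear of the usual scatter, but they do not show a real effect of the hydroxy group on toxicity in this test on either core: the same change on two cores in this assay, an at least 1.5-fold lower number (0.19 log units; that floor lies within the scatter) from compound 3 to compound 2 and a 1.6-fold lower number (0.20 log units; within the scatter) from compound 1 to compound 4; the limit leaves it open whether they differ

Compound 3 is reported only as a limit, > 100000 nM, so the step on its core has a floor and no fixed size, and the data cannot show that the change has the same size on both cores.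

The compounds shown leave open whether another group at the same place, such as an amine, a methoxy group or a carboxylic acid, would give a step from compound 1 that lies beyond the scatter. From the compounds shown here alone, both hydroxy compounds also carry the bromo group, and so it stays open whether the step would hold with a methyl group in place of that bromo group.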